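A Different Ring Next to the Ring Nitrogen

A few compounds are considered here, and "the series" means these few. Any claim that something is new, unique, unknown or untested is made for them only; others in the source may bear on it.

Of the compounds shown here, two have been measured so far in a functional assay on CHO-K1 cells for antagonist activity at transient receptor potential cation channel subfamily V member 1 (Homo sapiens), read by FLIPR; a higher number here means a weaker inhibitor, a lower number a stronger inhibitor. Compound 1 `Cc1ccc(Cl)cc1Nc1nc(C(F)(F)F)ccc1CNC(=O)C(C)c1ccc(NS(C)(=O)=O)c(F)c1` gives 140 nM in this assay, the higher of the two numbers. Compound 2 `C[C@H](C(=O)NCc1ccc(C(F)(F)F)nc1N1CC[C@@H](OCc2ccccc2)C1)c1ccc(NS(C)(=O)=O)c(F)c1` gives 50 nM in this assay, a lower number that lies beyond the usual scatter, so compound 2 is the stronger inhibitor of the pair. Compound 2 carries a non-aromatic ring joined through its nitrogen at the place on the shared core where compound 1 carries the (5-chloro-2-methylphenyl)amino group, which shows that a nitrogen-linked ring at this place is tolerated.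

Compound 3 `CC(C(=O)NCc1ccc(C(F)(F)F)nc1N1CC=CCC1)c1ccc(NS(C)(=O)=O)c(F)c1` has not yet been measured. It differs from compound 1 as follows: a group of 6 heavy atoms (5 carbon, 1 nitrogen; one six-membered non-aromatic ring with 1 hetero atom) in place of a group of 9 heavy atoms (7 carbon, 1 nitrogen, 1 chlorine; one six-membered aromatic ring of carbon only), on an aromatic carbon

Compound 1 gives 140 nM in this assay, while compound 2, with a different nitrogen-linked ring at this place, gives 50 nM. On that basis a modest step toward a lower number is expected, a 1.4-fold lower number from compound 1 to compound 3 (0.15 log units; within the scatter), though the result could also stay within the scatter. Compound 3 is estimated at 100 nM, within a range from 30 nM to 350 nM.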

Compound 3, half-maximal inhibitory concentration: 12.1 nM
Compound 3: the middle estimate sits 8.3-fold (0.92 log units) above what was measured, and the stated range ends above it.
By their numbers in this assay, from the lowest: compound 3; then compound 2; then compound 1.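

In this assay, putting a six-membered non-aromatic ring, joined through its nitrogen and holding one double bond, in place of the (5-chloro-2-methylphenyl)amino group gives a 12-fold lower number from compound 1 to compound 3 (1.06 log units; beyond the scatter), a large step and well beyond the usual scatter. At this place, on an aromatic carbon next to the ring nitrogen, the aromatic ring and the hydrogen-bond donor of the group that leaves are therefore not required for stronger inhibition, and a group of 6 heavy atoms in place of 9 goes with a much lower number. This single step changes the ring, the group's size and the donor count all at once, so it cannot say which of these changes matters, and no measurement available here explains the drop.

The compounds shown leave open whether the double bond itself counts, which a fully saturated piperidine ring at the same place would test. They also leave open how far the ring can change, for example to a morpholine ring, or whether an open-chain dimethylamino group would serve there as well.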